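The compounds below may be only part of what the source reports. "The series", "measured", "known", "first", "only" and "open" are said of these compounds alone.

Measured in an ADME assay on WI-38 cells (Homo sapiens) for inhibition, read by MTT assay, with a stated time of 72 h; on this read-out higher numbers stand for weaker inhibition and lower numbers for stronger inhibition:
compound 1 `O=C(OC1(C(=O)Nc2ccc([N+](=O)[O-])cc2)CCCCC1)c1ccc(C(F)(F)F)cc1` gives 185 nM;
compound 2 `O=C(OC1(C(=O)Nc2ccc([N+](=O)[O-])cc2)CCCCC1)c1ccc(Br)cc1` gives 523 nM;
compound 3 `O=C(/C=C/c1ccccc1)OC1(C(=O)Nc2ccc([N+](=O)[O-])cc2)CCCCC1` gives 41 nM.

Compound 3 stands lowest of the three, the strongest inhibitor here, with a 4.5-fold lower number from compound 1 to compound 3 (0.65 log units; beyond the scatter) and a 13-fold lower number from compound 2 to compound 3 (1.11 log units; beyond the scatter) both beyond the scatter. Compound 4 `CCC(=O)OC1(C(=O)Nc2ccc([N+](=O)[O-])cc2)CCCCC1` is not yet measured. The change from compound 3 is ethyl in place of 2-phenylethenyl on a carbonyl carbon. The two steps that touch the same carbonyl carbon, a 4.5-fold lower number from compound 1 to compound 3 (0.65 log units; beyond the scatter) and a 13-fold lower number from compound 2 to compound 3 (1.11 log units; beyond the scatter), show that this position moves the number strongly; both went towards compound 3. Among the compounds with values here, no measured compound carries a short chain there, so the direction rests on compound 3 being the extreme. A modest rise in the number is expected, with wide uncertainty, giving a 9.8-fold higher number from compound 3 to compound 4 (0.99 log units; beyond the scatter). For compound 4 the estimate is 400 nM, range 80 nM to 2500 nM.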

Compound 4, half-maximal inhibitory concentration: 44.6 nM
Beside the measured number, compound 4's estimate is 9.0-fold (0.95 log units) above it; the whole stated range lies above it.
By their numbers in this assay, from the lowest: compounds 3 and 4 (each within the scatter of the next); then compound 1; then compound 2.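

In this assay, the large 2-phenylethenyl group can give way to ethyl on this carbonyl carbon with no change beyond the scatter (a 1.1-fold higher number from compound 3 to compound 4 (0.04 log units; within the scatter)), so neither its aromatic ring nor its double bond is required for a low number. Ethyl also compares with both substituted phenyl groups (a 4.1-fold lower number from compound 1 to compound 4 (0.62 log units; beyond the scatter); a 12-fold lower number from compound 2 to compound 4 (1.07 log units; beyond the scatter)), which places the higher numbers with 4-(trifluoromethyl)phenyl and 4-bromophenyl, not with the short chain. No evidence at hand explains these differences.

Still open, on these data alone, is whether methyl, a longer chain such as butyl, or unsubstituted phenyl would hold this level on the same carbonyl carbon. An amine or a carboxylic acid at this place also remains untested in the compounds shown.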